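Swapping a nitrile-tipped chain for a small oxygen ring

A few compounds are considered here, and "the series" means these few. Any claim that something is new, unique, unknown or untested is made for them only; others in the source may bear on it.

Compound 1: `CC(C)CCn1nc(C(=O)N[C@H]2COc3ccccc3N(C)C2=S)nc1Cc1ccccc1`, 3640 nM
Compound 2: `CN1C(=S)[C@@H](NC(=O)c2nc(Cc3ccccc3)n(CCCCC#N)n2)COc2ccccc21`, 2680 nM

In a functional assay on HT-29 cells (Homo sapiens) for inhibition, read by luminescence and CellTiter-Glo, with a stated time of 24 h (on this read-out lower numbers stand for an effect already at smaller amounts and higher numbers for an effect only at larger amounts of compound), compound 2 gives the lowest of the two numbers, yet a 1.4-fold lower number from compound 1 to compound 2 (0.13 log units; within the scatter), so the two compounds cannot be told apart. Compound 3 `CN1C(=S)[C@@H](NC(=O)c2nc(Cc3ccccc3)n(C3CCOC3)n2)COc2ccccc21` carries oxolan-3-yl in place of 4-cyanobutyl on an aromatic nitrogen. Within the data shown here, the one measured step, 2-cyanoethyl in place of isopropyl on the chain, changed little; no measured step touches a ring at this place, so no reasoned direction exists. A step within the scatter is therefore expected, a 1.2-fold higher number from compound 2 to compound 3 (0.08 log units; within the scatter). Compound 3 is estimated at 3200 nM, between 1100 nM and 9500 nM.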

Compound 3, half-maximal effective concentration: 1580 nM
Beside the measured number, compound 3's estimate is 2.0-fold (0.31 log units) above it; the measured number falls inside the stated range.
By their numbers in this assay, from the lowest: compounds 3, 2 and 1 (each within the scatter of the next, the first and the last beyond it).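

In this assay, among these compounds, a ring on this aromatic nitrogen holds up against the open chains: oxolan-3-yl in place of 4-cyanobutyl gives a 1.7-fold lower number from compound 2 to compound 3 (0.23 log units; within the scatter) and, in place of isopentyl, a 2.3-fold lower number from compound 1 to compound 3 (0.36 log units; beyond the scatter) as the first step here beyond the scatter, though a modest one. So this position accepts a closed ring as well as a flexible chain. Nothing measured here explains the result. Going by these compounds, what a cyclopentyl ring, with carbon in place of the ring oxygen, or a pyrrolidine ring, with an amine there, would give at this nitrogen stays open.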